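Coumarin-free notes: series migration read-out, compound 2 to compound 4

This account rests on a few compounds, and the source may have more. Where it says the series, first, only, none or still open, it means among the compounds named here.

Among the measured compounds shown here, the three measured members share one core and differ at the chain carbon bound to an aromatic carbon and in the group linking the core to the halogenated ring. In a functional assay on HT-1080 cells (Homo sapiens), read by transwell migration, with a stated time of 24 h, tested at 1 uM (on this read-out higher numbers stand for a weaker effect at the one concentration tested and lower numbers for a stronger effect), compound 1 `CC(=O)OCc1ccc2oc(=O)c(C(=O)Nc3cccc(Cl)c3)cc2c1` gives 66.9%, compound 2 `CCCCCCC(=O)OCc1ccc2oc(=O)c(C(=O)Oc3cccc(Br)c3)cc2c1` gives 55.6%, and compound 3 `NCc1ccc2oc(=O)c(C(=O)Oc3cccc(Cl)c3)cc2c1` gives 86.6%. Compound 2 has the lowest number of the three, and so the strongest effect at the single concentration; the nearest is compound 1, higher by a margin beyond the scatter, and the furthest is compound 3, higher by a margin also beyond the scatter.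

Compound 4 `CC(=O)NCc1ccc2oc(=O)c(C(=O)Oc3cccc(Br)c3)cc2c1` is not yet measured. It differs from compound 2 in one place: acetamido in place of (hexylcarbonyl)oxy on a saturated chain carbon bound to an aromatic carbon.

For the measured compounds named here, no single-change step between measured compounds exists to size this move, so the expectation rests on the spread of the three values. Compound 3, carrying an unacylated aminomethyl, gives 86.6%, and compound 1, carrying the shorter acyloxymethyl, gives 66.9%; both sit above compound 2. The change in this assay from compound 2 to compound 4 is therefore expected to raise the number, toward a weaker effect, by a number 16.4 percentage points higher from compound 2 to compound 4 (beyond the scatter), clearly beyond the scatter. Compound 4 is estimated at 72%, within 58% to 88%.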

Compound 4, a percentage reported as activity, at one concentration (the size of the read-out at that concentration, not a potency): 36.9%
For compound 4 the middle estimate is 35.1 percentage points above the measured one; measured number below the stated range.
By their numbers in this assay, from the lowest: compound 4; then compound 2; then compound 1; then compound 3.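

In this assay the saturated chain carbon bound to an aromatic carbon now has its first single-change step, which reads a number 18.7 percentage points lower from compound 2 to compound 4 (beyond the scatter) with acetamido in place of (hexylcarbonyl)oxy. This shows that the group at this position alone can shift the read-out, and that in this pair the effect at the one concentration tested does not depend on keeping the (hexylcarbonyl)oxy group, since the acetamido group with 4 heavy atoms and 1 hydrogen-bond donor replaces one with 9 heavy atoms and 0 hydrogen-bond donors and the number still falls. Nothing available bears on why the step runs in this direction.

The compounds shown leave open whether the step follows the change of linking atom from oxygen to nitrogen, the change of chain length or both, since the two change together in this single pair. An acetoxy group or a heptanamido group at the same position, with the rest of compound 4 unchanged, would separate the two, and a urea or a sulfonamide there would show whether the step extends beyond acyl amides.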